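The source may hold more compounds than are shown below. What is called first, only, known or untested is meant among the compounds shown, and "the series" means these compounds.

Measured in a functional assay on Jurkat cells (Homo sapiens) for antiproliferative activity, read by MTT assay, with a stated time of 72 h; on this read-out higher numbers stand for weaker inhibition and lower numbers for stronger inhibition:
Compound 1 `COc1cccc(-c2ncnn2-c2cc(OC)c(OC)c(OC)c2)c1`: > 10000 nM
Compound 2 `CCOc1cccc(-c2ncnn2-c2cc(OC)c(OC)c(OC)c2)c1`: > 10000 nM
Compound 3 `COc1cc(-n2ncnc2-c2cccc([N+](=O)[O-])c2)cc(OC)c1OC`: > 10000 nM

Each of these entries is a limit of the assay and not a number. Compound 1 therefore has no exact place on the scale, and it shares its standing with the other two compounds, as the limit of > 10000 nM in this assay, at which 3 of the 3 values shown sit, shows.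

Compound 4 `COc1ccccc1-c1ncnn1-c1cc(OC)c(OC)c(OC)c1` has not yet been measured in this assay. It carries 2-methoxyphenyl in place of the 3-methoxyphenyl of compound 1, on an aromatic carbon of a five-membered aromatic ring with 3 nitrogen: 2-methoxyphenyl in place of 3-methoxyphenyl on an aromatic carbon. The two compounds have the same atoms, joined differently.

The measured steps offer little guidance. They are a step that the two limits leave unreadable from compound 1 to compound 2, a step that the two limits leave unreadable from compound 1 to compound 3 and a step that the two limits leave unreadable from compound 2 to compound 3. None of them gives a size, and none involves the 2-methoxyphenyl group. With no readable step to carry over, no change beyond the scatter is expected, and compound 4 is expected to report a limit as well.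

The expected change is a step that the limit leaves unreadable from compound 1 to compound 4. The estimate for compound 4 is 12000 nM, with an expected range from 3000 nM to 40000 nM.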

Compound 4, half-maximal inhibitory concentration: > 10000 nM
Compound 4 was reported as a limit; the forecaster's own chance of this, stated with the estimate: 85%; the middle value lies beyond the limit too.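

In this assay compound 4 is also reported as a limit and not a number, so the step from compound 1 to compound 4 cannot be read, and the four compounds share one standing: the limit of > 10000 nM in this assay, at which 4 of the 4 values shown sit.

The compounds shown leave open how 2-methoxyphenyl and 3-methoxyphenyl compare, and whether any change to the shared core gives a measurable value.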